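The source may hold more compounds than are shown below. What is called first, only, known or untested is meant among the compounds shown, and "the series" means these compounds.

Of the compounds shown here, three built on one shared core have been measured in a functional assay on HEp-2 cells (Homo sapiens) for inhibition, read by sulforhodamine B assay, with a stated time of 48 h, tested at 100 uM; on this read-out lower numbers stand for less inhibition of growth and higher numbers for more inhibition of growth at the one concentration tested. Compound 1 `O=c1c(C(=S)Nc2ccccc2)coc2ccccc12` gives 32% in this assay. Compound 2 `O=c1c(C2N=C(c3ccccc3)SS2)coc2ccccc12` gives 48% in this assay, the highest of the three numbers; compound 1 stands nearest to it and compound 3 furthest, and both gaps lie beyond the scatter. Compound 3 `O=c1c(C2N=C(c3ccccc3)SS2)coc2cc(Cl)ccc12` gives 31% in this assay. Going by the values given here, the single step that separates compound 2 from compound 3, chloro in place of hydrogen on an aromatic carbon, amounts to a number 17 percentage points lower from compound 2 to compound 3 (beyond the scatter), a modest drop.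

Compound 4 `Cc1ccc2occ(C3N=C(c4ccccc4)SS3)c(=O)c2c1` has not yet been measured in this assay. It differs from compound 2 in one place: methyl in place of hydrogen on an aromatic carbon. Among the compounds with values here, only one measured step bears on this change, namely a number 17 percentage points lower from compound 2 to compound 3 (beyond the scatter), in which a different small group likewise entered an aromatic carbon of the core of compound 2 and the number fell. On that single precedent, a small group entering the aromatic ring of compound 2 is expected to lower growth inhibition somewhat, though the group and its place differ and the precedent is thin, so a step within the scatter cannot be ruled out. Compound 4 is therefore estimated to give 38% in this assay, within a range of 20% to 55%. This estimate corresponds to an expected step of a number 10 percentage points lower from compound 2 to compound 4 (within the scatter).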

Compound 4, percent growth inhibition at one concentration: 43%
Compound 4: middle estimate off by 5 percentage points, on the low side; measured number inside the range.
By their numbers in this assay, from the lowest: compounds 3 and 1 (each within the scatter of the next); then compounds 4 and 2 (each within the scatter of the next).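

On the carbon that is meta to a fused ring and para to a fused ring, methyl in place of hydrogen gives a number 5 percentage points lower from compound 2 to compound 4 (within the scatter) in this assay, so at this position and with this group the measured growth inhibition of compound 2 is kept within the usual variation of the test. The earlier chloro change, a number 17 percentage points lower from compound 2 to compound 3 (beyond the scatter), was the only substitution on the aromatic ring until now and lay beyond the scatter, at another carbon, so compound 4 now goes against any reading that every small group entering this ring reduces the number. Nothing available explains why methyl is accommodated here, and no separate measurement bears on the cause of this result.

As far as these compounds go, whether this carbon accepts other groups equally remains open, since an amine, a carboxylic acid, a methoxy group or a longer chain such as propyl could behave quite differently from methyl. The compounds shown also leave apart the effects of group and place, as chloro on the carbon that carries methyl in compound 4 would be needed to separate them.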